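The source may hold more compounds than are shown below. What is called first, only, known or untested is meant among the compounds shown, and "the series" means these compounds.

Measured so far in a physicochemical assay for solubility, with a stated time of 18 h, at pH 7.4; on this read-out lower numbers stand for lower solubility and higher numbers for higher solubility:
Compound 1 `Cc1cc(C)cc(Cc2ccc3c(NCCCNCc4ccco4)ccnc3c2)c1` gives 4200 nM.
Compound 2 `COc1cccc(CNCCCNc2ccnc3cc(Cc4cc(C)cc(C)c4)ccc23)c1O` gives 4200 nM.
Compound 3 `COc1cccc(Oc2ccc3c(NCCCNCc4ccco4)ccnc3c2)c1` gives 14500 nM.

Compound 1 and compound 2 share one core and differ in a single place: 2-hydroxy-3-methoxyphenyl in place of furan-2-yl on a saturated chain carbon bound to an amine nitrogen. On this assay that change made no change at the digits printed from compound 1 to compound 2 (within the scatter), so the two compounds cannot be told apart on solubility.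

Compound 3 is built on a second core. The difference between the two cores is 3-methoxyphenoxy in place of 3,5-dimethylbenzyl on an aromatic carbon, and it made a 3.5-fold higher number from compound 1 to compound 3 (0.54 log units; beyond the scatter). Compound 3 therefore holds the highest solubility of the three measured compounds, and both of the others lie a clear step beneath it.

Compound 4 `COc1cccc(Oc2ccc3c(NCCCNCc4cccc(OC)c4O)ccnc3c2)c1` has not yet been measured. It relates to compound 3 exactly as compound 2 relates to compound 1: 2-hydroxy-3-methoxyphenyl in place of furan-2-yl on a saturated chain carbon bound to an amine nitrogen. The place of the exchange is described in the same words for both pairs, so this is the same change carried over to the second core.

Because the earlier instance of this change gave no change at the digits printed from compound 1 to compound 2 (within the scatter), the step from compound 3 to compound 4 is expected to be a 1.0-fold lower number from compound 3 to compound 4 (0.02 log units; within the scatter). Compound 4 is accordingly estimated at 14000 nM in this assay, with a likely range from 6000 nM to 32000 nM.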

Compound 4, solubility: 14500 nM
Estimate against measurement, compound 4: 1.0-fold (0.02 log units) below; the range from low to high includes it.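

In this assay the exchange of furan-2-yl for 2-hydroxy-3-methoxyphenyl on a saturated chain carbon bound to an amine nitrogen gave no change at the digits printed from compound 3 to compound 4 (within the scatter) on the second core, matching the no change at the digits printed from compound 1 to compound 2 (within the scatter) seen on the first, and the core difference likewise gave a 3.5-fold higher number from compound 2 to compound 4 (0.54 log units; beyond the scatter) with the new group in place, just as it gave a 3.5-fold higher number from compound 1 to compound 3 (0.54 log units; beyond the scatter) with furan-2-yl. So in these four compounds the exchange carried from one core to the other without altering the reading, and the effect of the core difference held whichever of the two groups was present. This is one repeat of the exchange on two cores in one assay, so it shows no general rule for the series, and nothing given here bears on why the exchange left the reading level.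

The compounds shown leave open whether a third core would behave the same way. They also leave open what would happen with an amine or a carboxylic acid in place of furan-2-yl, or with a longer chain.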